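Chloro for amino on the shared core: a projected step

The compounds below may be only part of what the source reports. "The series", "measured", "known", "first", "only" and "open" are said of these compounds alone.

Two members of the series have been measured in a functional assay on SK-MEL-28 cells (Homo sapiens) for cytotoxicity, read by sulforhodamine B assay, with a stated time of 48 h; a higher number here means a weaker inhibitor of growth, a lower number a stronger inhibitor of growth. Compound 1 `Nc1nc(Cl)c2ncn(Cc3ccccc3CCl)c2n1` gives 20900 nM and has the higher of the two numbers on record; compound 2 `ClCc1ccccc1Cn1cnc2ncnc(Cl)c21` gives 18600 nM, and the gap lies within the scatter, so the two cannot be ordered. Within the data shown here, no step between measured compounds that differ in one place is available. Compound 3 `ClCc1ccccc1Cn1cnc2c(Cl)nc(Cl)nc21` has not been measured; it differs from compound 1 by chloro in place of amino on an aromatic carbon. The two measured values show that the amino group of compound 1, or its absence in compound 2, leaves the number about where it is; chloro entering in its place is expected to move the number only slightly, if at all, toward a lower value. Compound 3 is therefore expected to give 14000 nM, in the range 5000 nM to 35000 nM. The expected step from compound 1 to compound 3 is a 1.5-fold lower number from compound 1 to compound 3 (0.17 log units; within the scatter), which is estimated to remain within the scatter.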

Compound 3, concentration for total growth inhibition: 3310 nM
Compound 3: the middle estimate sits 4.2-fold (0.63 log units) above what was measured, outside the stated range (below it).
By their numbers in this assay, from the lowest: compound 3; then compounds 2 and 1 (each within the scatter of the next).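

In this assay, among these compounds, chloro in place of amino on this aromatic carbon, between two ring nitrogen atoms, gives a 6.3-fold lower number from compound 1 to compound 3 (0.80 log units; beyond the scatter), so the position responds to the change even though the earlier compounds showed no separation. Compound 2, with neither group on this carbon, gives 18600 nM and stays within the scatter of compound 1, which suggests that losing amino alone does not account for the step and that the entering chloro matters. No measurement available here explains the step. As far as these compounds go, whether a methoxy group, a methylamino group or a bromo group on this carbon would also lower the number remains open. Also open, from the compounds shown here alone, is whether the step depends on the chloro group already on the shared core or on the chloromethyl group.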